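The compounds below may be only part of what the source reports. "The series", "measured", "known", "first", "only" and "open" are said of these compounds alone.

Series notes. In a functional assay on the whole organism (stomach, strain beagle) for inhibition, with Canis familiaris (Canis lupus familiaris) as the target, with a stated time of 2 h, at a dose of 16 mg/kg (on this read-out higher numbers stand for a stronger effect at the one dose given and lower numbers for a weaker effect), compound 1 `N=C(CSCc1ccccc1)NC[C@@H]1C[C@H]2CC[C@H]1C2` gives 19%. In this assay compound 2 `N=C(CCS)NCc1ccccc1` gives 18%. Of the two numbers shown, the one for compound 2 is the lower, but compound 1 lies within the scatter of it, so no difference between the two can be read and both stand at the same low level of inhibition. For the measured compounds named here, no two measured compounds differ in one place, so no measured step is available in this assay. Compound 3 `N=C(CO)NCc1ccccc1` has not yet been measured; it differs from compound 2 by hydroxy in place of sulfanylmethyl on a saturated chain carbon bound to a carbon with a double bond to nitrogen. Going by the values given here, no measured pair shows the outcome of this change, and with compound 2 at 18% the expected step is a number 3 percentage points lower from compound 2 to compound 3 (within the scatter), a change within the scatter in no particular direction. For compound 3 the estimated result in this assay is 15%, with a range from 0% to 32%.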

Compound 3, a percentage reported as inhibition, in the whole organism at one dose (the size of the read-out at that dose, not a potency): 0%
Compound 3: middle estimate off by 15 percentage points, on the high side; low and high end bracket the measured number.
By their numbers in this assay, from the lowest: compound 3; then compounds 2 and 1 (each within the scatter of the next).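

In this assay, for the compounds shown here, hydroxy in place of sulfanylmethyl on a saturated chain carbon bound to a carbon with a double bond to nitrogen gives a number 18 percentage points lower from compound 2 to compound 3 (beyond the scatter), the first step that can be read. The group at this place therefore bears on the read-out, even though compound 2 itself stands at a low level. The change swaps the carbon and sulfur of sulfanylmethyl for the oxygen of hydroxy, and no measurement shown accounts for the step.

As far as these compounds go, whether the sulfur or the chain length carries the difference stays open, as the step alters both at once. A 2-hydroxyethyl group or a sulfanyl group at this place would separate the two, and an amine or a carboxylic acid there remains an open question.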